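Working notes: thiophen-2-yl in place of isopropyl

The source may hold more compounds than are shown below. What is called first, only, known or untested is meant among the compounds shown, and "the series" means these compounds.

Measured so far:
compound 1 `CC1CN=C(c2ccc(-c3noc(-c4ccc(Cl)c(Cl)c4)n3)cc2)N1`: 14700 nM
compound 2 `CC(C)c1noc(-c2ccc(C3=NCCN3)cc2)n1`: 22500 nM

In an assay for inhibition of Amine oxidase [flavin-containing] A (Homo sapiens), read by fluorescence and spectrophotometry, using microsomes, with stated times of 30 min and 20 min (a higher number here means a weaker inhibitor, a lower number a stronger inhibitor), compound 1 gives 14700 nM, and compound 2 gives 22500 nM. Compound 2 has the higher of the two numbers, but its gap to compound 1 lies within the scatter, so no order between them can be read. Compound 3 `c1csc(-c2noc(-c3ccc(C4=NCCN4)cc3)n2)c1` differs from compound 2 by thiophen-2-yl in place of isopropyl on an aromatic carbon. Going by the values given here, no measured pair shows this change, so the expected step in this assay is small and uncertain. Compound 1, which carries an aromatic group at that position on another core, gives 14700 nM, which suggests a slightly lower number. For compound 3 the estimate is 12000 nM, range 4000 nM to 40000 nM, an expected step of a 1.9-fold lower number from compound 2 to compound 3 (0.27 log units; within the scatter).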

Compound 3, half-maximal inhibitory concentration: 1570 nM
Beside the measured number, compound 3's estimate is 7.6-fold (0.88 log units) above it; measured number below the stated range.
By their numbers in this assay, from the lowest: compound 3; then compounds 1 and 2 (each within the scatter of the next).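

In this assay, the substituent at this position on the shared core matters: thiophen-2-yl in place of isopropyl gives a 14-fold lower number from compound 2 to compound 3 (1.16 log units; beyond the scatter) on an aromatic carbon. Compound 1 and compound 2 differ in more than one place and could not isolate this change. The data offer no measured explanation for the size of this step. As far as these compounds go, it remains open whether the step belongs to the ring as a whole or to its sulfur; phenyl or furan-2-yl at this position on the same core would test that.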